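Swapping hydroxy for a selenium-bearing group on a shared core

The compounds below may be only part of what the source reports. "The series", "measured", "known", "first", "only" and "open" are said of these compounds alone.

Measured in a functional assay on A-431 cells (Homo sapiens) for antiproliferative activity, read by sulforhodamine B assay, with a stated time of 72 h; on this read-out higher numbers stand for weaker inhibition and lower numbers for stronger inhibition:
- compound 1 `C=C1CC(CBr)(c2ccccc2)OC1=O`: 1480 nM
- compound 2 `C=C1CC(CO)(c2ccccc2)OC1=O`: 4060 nM

Of these two compounds, compound 2 has the higher number at 4060 nM, so it is the weaker inhibitor. Among the measured compounds shown here, its only neighbour is compound 1, and the two differ in one place. That step, a 2.7-fold higher number from compound 1 to compound 2 (0.44 log units; beyond the scatter), is modest but beyond the usual scatter.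

The next compound is compound 3 `C=C1CC(C[Se]c2ccccc2)(c2ccccc2)OC1=O`. Its change from compound 2 is a group of 7 heavy atoms (6 carbon, 1 selenium; one six-membered aromatic ring of carbon only) in place of one oxygen atom, on a saturated chain carbon bound to a saturated ring carbon. The hydroxy leaves a saturated chain carbon bound to a saturated ring carbon, the same place that changed between the two measured compounds.

For the measured compounds named here, only that one step bears on this change, and it says nothing directly about a selenium-containing group. Compound 1, which lacks the hydroxy, gives the lower number, with a 2.7-fold higher number from compound 1 to compound 2 (0.44 log units; beyond the scatter). A modest move towards lower numbers in this assay is therefore expected, though with wide uncertainty. The estimated step is a 2.7-fold lower number from compound 2 to compound 3 (0.43 log units; beyond the scatter). For compound 3 the expected value is 1500 nM, with an estimated range of 500 nM to 4500 nM.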

Compound 3, half-maximal inhibitory concentration: 1270 nM
Compound 3: middle estimate off by 1.2-fold (0.07 log units), on the high side, and the stated range covers the measured number.
By their numbers in this assay, from the lowest: compounds 3 and 1 (each within the scatter of the next); then compound 2.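

In this assay, the new result shows that this position can carry a far larger group than a single oxygen or bromine atom without the number rising: the phenylselenyl-type group, with its 7 heavy atoms and aromatic ring, gives a 3.2-fold lower number from compound 2 to compound 3 (0.50 log units; beyond the scatter). That group and bromo are very different in size and makeup, yet they give numbers that cannot be told apart, with a 1.2-fold lower number from compound 1 to compound 3 (0.07 log units; within the scatter), so among these three compounds it is the hydroxy of compound 2 that stands apart, with the highest number. No measurement offered here explains why these groups compare as they do.

As far as these compounds go, what remains open is which part of the new group matters, the selenium atom or the aromatic ring, as the two enter together in compound 3. A group with sulfur in place of selenium would test the first, and an amine or a longer carbon chain on the same saturated chain carbon would show whether the hydroxy result extends to other groups.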